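Cytotoxicity in MT4 cells: from an oxadiazole to a thiophene

A few compounds are considered here, and "the series" means these few. Any claim that something is new, unique, unknown or untested is made for them only; others in the source may bear on it.

Compound 1 `COC(=O)N[C@H](C(=O)NN(CCC[C@@](O)(Cc1ccccc1)C(=O)N[C@H]1c2ccccc2C[C@H]1O)Cc1ccc(Br)cc1)C(C)(C)C`: in an ADME assay on MT4 cells (Homo sapiens) for cytotoxicity (on this read-out lower numbers stand for higher toxicity in this test and higher numbers for lower toxicity in this test), compound 1 gives > 10000 nM, a limit of the assay rather than a number.
Compound 2 `COC(=O)N[C@H](C(=O)NN(CCC[C@](O)(Cc1ccccc1)C(=O)N[C@H]1c2ccccc2C[C@H]1O)Cc1ccc(Br)cc1)C(C)(C)C`: in this assay compound 2 gives > 10000 nM, again a limit of the assay.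
Compound 3 `COC(=O)N[C@H](C(=O)NN(CCC[C@@](O)(Cc1ccccc1)C(=O)N[C@H]1c2ccccc2C[C@H]1O)Cc1ccc(-c2noc(C)n2)cc1)C(C)(C)C`: in this assay compound 3 gives > 10000 nM, also a limit of the assay.

Compound 3 therefore stands where every measured compound stands, at the limit, as the limit of > 10000 nM in this assay, at which 3 of the 3 values shown sit, records. Neither measured step can be read: a step that the two limits leave unreadable from compound 1 to compound 2, and a step that the two limits leave unreadable from compound 1 to compound 3. The change from compound 1 to compound 2 rests on (the fact that compounds 1 and 2 differ only in the configuration as drawn), and gives no readable size.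

Compound 4 `COC(=O)N[C@H](C(=O)NN(CCC[C@@](O)(Cc1ccccc1)C(=O)N[C@H]1c2ccccc2C[C@H]1O)Cc1ccc(-c2ccsc2)cc1)C(C)(C)C` differs from compound 3 by thiophen-3-yl in place of 5-methyl-1,2,4-oxadiazol-3-yl on an aromatic carbon. Among the compounds with values here, no measured step in this assay bears on this exchange with a readable size, and every value so far sits at the limit, so compound 4 is expected to sit there as well, with a step that the limit leaves unreadable from compound 3 to compound 4 expected to be no step beyond the scatter. Compound 4 is estimated at 20000 nM, between 8000 nM and 50000 nM, and most likely reported only as a limit.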

Compound 4, half-maximal cytotoxic concentration: > 10000 nM
Compound 4: only a limit was reported; the forecaster's own chance of this, stated with the estimate: 80%; the middle value lies beyond the limit too.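

In this assay compound 4 gives > 10000 nM, again a limit of the assay. The steps from compound 1 and from compound 3 to compound 4 therefore cannot be read. The compounds shown leave open whether the bromo, oxadiazole and thiophene compounds differ at all in cytotoxicity.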